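A few compounds are considered here, and "the series" means these few. Any claim that something is new, unique, unknown or untested is made for them only; others in the source may bear on it.

Compound 3 `COc1cc(/C=C/c2nc(NC3CC3)c3sccc3n2)cc(OC)c1OC` was tested in a functional assay on L02 cells (Homo sapiens) for inhibition, read by Griess assay, with stated times of 1 h and 24 h; a lower number here means a stronger inhibitor, a higher number a weaker inhibitor. Its result is a limit of the assay rather than a number: compound 3 gives > 1000000 nM. Two other compounds in the same study also sit at limits. Compound 1 `CCCc1nn(C)c2c(NCc3ccc(F)cc3)nc(CCc3cccnc3)nc12` gives < 40000 nM, again a limit and not a number. Compound 2 `COc1cc(/C=C/c2nc(Cl)cc(NC(C)C)n2)cc(OC)c1OC` gives < 40000 nM, likewise a limit. So of the three results shown, two sit at the limit of < 40000 nM in this assay, at which 2 of the 3 values shown sit, and one, that of compound 3, at the limit of > 1000000 nM in this assay, at which 1 of the 3 values shown sits. With only limits available, no step between any two of these compounds can be sized, and compound 3 can only be said to be the one reported at the upper limit.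

Compound 4 `COc1cc(/C=C/c2nc(Nc3ccc(C(F)(F)F)cc3)c3sccc3n2)cc(OC)c1OC` has not been measured. It differs from compound 3 in one place: 4-(trifluoromethyl)phenyl in place of cyclopropyl on a nitrogen on an aromatic ring. Within the data shown here, no measured pair in this set shows what such a change does. Compound 3 sits at the upper limit > 1000000 nM. From there the step of an at least 3.3-fold lower number from compound 3 to compound 4 (0.52 log units; beyond the scatter) is expected to move toward stronger inhibition, though it may be none beyond the scatter. Compound 4 is expected to give 300000 nM, with a range from 30000 nM to 2000000 nM and a real chance that this assay again reports only a limit.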

Compound 4, half-maximal inhibitory concentration: 436000 nM
The estimate for compound 4 lay 1.5-fold (0.16 log units) below the measured number; the measured number falls inside the stated range.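

Among these compounds, replacing cyclopropyl with 4-(trifluoromethyl)phenyl on a nitrogen on an aromatic ring gives, in this assay, an at least 2.2-fold lower number from compound 3 to compound 4 (0.36 log units; beyond the scatter), the first change in this set whose size can be read at all. The entering group has 10 heavy atoms where the leaving one has 3, and this much larger group at this position goes with stronger inhibition, not weaker, and with a measured number in place of a limit. The size of the step is only a minimum, since compound 3 is reported at a limit and not at a number: the limit of > 1000000 nM in this assay, at which 1 of the 4 values shown sits.

The compounds shown do not separate the part played by the phenyl ring from that of the trifluoromethyl group on it, and a plain phenyl on the same nitrogen would tell the two apart. Steps from compound 1 and compound 2 to the others cannot be read, as these compounds differ from the rest in more than one place, so it also remains open how a cyclic amine such as morpholine in place of the cyclopropylamino group would behave on the shared core.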